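The source may hold more compounds than are shown below. What is called first, only, known or untested is meant among the compounds shown, and "the series" means these compounds.

Three compounds share a sulfonyl-substituted indole core carrying an amide side chain. Compound 1 `Cc1cc(C)cc(S(=O)(=O)c2c(C(=O)NCCOc3ccccc3)[nH]c3ccc(Cl)cc23)c1` gives 207000 nM in an ADME assay on CCRF-CEM cells (Homo sapiens) for cytotoxicity, read by cell counting (a higher number here means that more compound is tolerated, a lower number that less compound is tolerated), and compound 2 `Cc1cc(C)cc(S(=O)(=O)c2c(C(=O)NCc3ccccc3)[nH]c3ccc(Br)cc23)c1` gives 172000 nM in this assay. Compound 3 `Cc1cc(C)cc(S(=O)(=O)c2c(C(=O)NCN3CCCCC3)[nH]c3ccc([N+](=O)[O-])cc23)c1` gives 12000 nM in this assay, the lowest of the three numbers; the gaps from compound 3 to compound 2 and to compound 1 both lie well beyond the usual scatter, so compound 3 is the least tolerated of the measured set.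

Compound 4 `Cc1cc(C)cc(S(=O)(=O)c2c(C(=O)NCc3ccccc3)[nH]c3ccc([N+](=O)[O-])cc23)c1` has not yet been measured. It differs from compound 3 in one place: phenyl in place of piperidin-1-yl on a saturated chain carbon bound to an amide-type nitrogen. In that side chain it matches compound 2, while it keeps the nitro group of compound 3. For the measured compounds named here, no single-change step between measured compounds tells how this exchange alone shifts the number. Because compound 2 carries the same benzyl amide and gives 172000 nM, compound 4 is expected to sit between compound 3 and compound 2, with an upward step of a 4.2-fold higher number from compound 3 to compound 4 (0.62 log units; beyond the scatter). The estimate for compound 4 is 50000 nM, with a range from 12000 nM to 200000 nM.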

Compound 4, half-maximal cytotoxic concentration: 8000 nM
The estimate for compound 4 lay 6.3-fold (0.80 log units) above the measured number, outside the stated range (below it).
By their numbers in this assay, from the lowest: compounds 4 and 3 (each within the scatter of the next); then compounds 2 and 1 (each within the scatter of the next).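

Exchanging piperidin-1-yl for phenyl on a saturated chain carbon bound to an amide-type nitrogen gives a 1.5-fold lower number from compound 3 to compound 4 (0.18 log units; within the scatter) in this assay and so does not move the number beyond the scatter while the nitro group is present. Keeping the benzyl amide and putting nitro in place of bromo on an aromatic carbon gives a 22-fold lower number from compound 2 to compound 4 (1.33 log units; beyond the scatter) and is the first single change in this set with a step beyond the scatter, so the low number of compound 3 can no longer be tied to its piperidin-1-yl group alone. No measurement shown here explains either step.

From the compounds shown here alone, it remains open whether bromo in place of nitro would raise the number as far with the piperidin-1-yl side chain as with the benzyl amide. How an amine or a carboxylic acid would read in place of nitro on that aromatic carbon is also unknown.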